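Series notes: cyclopentyl replacing isopropyl at the ketone side chain

The source may hold more compounds than are shown below. What is called first, only, known or untested is meant among the compounds shown, and "the series" means these compounds.

Measured so far, in an assay on HEK293 cells for positive allosteric modulation of metabotropic glutamate receptor 2 (Rattus norvegicus), read by thallium flux, with a stated time of 2.5 min; on this read-out lower numbers stand for an effect already at smaller amounts and higher numbers for an effect only at larger amounts of compound:
compound 1 `Cc1cc(C(=O)O)ccc1OCCCCOc1ccc(C(=O)CC(C)C)c(O)c1C`, 192 nM
compound 2 `Cc1c(OCCCCOc2ccc(C(=O)O)cc2)ccc(C(=O)CC(C)C)c1O`, 122 nM
compound 3 `Cc1c(OCCCCOc2ccc(C(=O)O)c(Cl)c2)ccc(C(=O)CC(C)C)c1O`, 151 nM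

Compound 1 gives the highest of the three numbers, yet its gaps to the others are small: a 1.6-fold lower number from compound 1 to compound 2 (0.20 log units; within the scatter) and a 1.3-fold lower number from compound 1 to compound 3 (0.10 log units; within the scatter), both within the scatter, as is a 1.2-fold higher number from compound 2 to compound 3 (0.09 log units; within the scatter). So far the series is flat.

Compound 4 `Cc1cc(C(=O)O)ccc1OCCCCOc1ccc(C(=O)CC2CCCC2)c(O)c1C` differs from compound 1 on the ketone side: cyclopentyl in place of isopropyl on a saturated chain carbon bound to a carbonyl carbon. Going by the values given here, none of the measured steps touches that position; they all concern the distal aryl ring and were within the scatter. No step beyond the scatter in this assay is therefore expected for compound 4. Compound 4 is estimated at 190 nM, with a range from 70 nM to 520 nM. For compound 4 this estimate means an expected 1.0-fold lower number from compound 1 to compound 4 (0.00 log units; within the scatter).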

Compound 4, half-maximal effective concentration: 608 nM
Estimate against measurement, compound 4: 3.2-fold (0.51 log units) below, outside the stated range (above it).
By their numbers in this assay, from the lowest: compounds 2, 3 and 1 (each within the scatter of the next); then compound 4.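

Going by these compounds alone, the ketone side chain is the first place to give a step beyond the scatter, with a 3.2-fold higher number from compound 1 to compound 4 (0.50 log units; beyond the scatter) for cyclopentyl in place of isopropyl on a saturated chain carbon bound to a carbonyl carbon. The earlier steps shown here, all away from this position, stayed within the scatter, so the side chain is the only position here with a response to a change of group. No evidence is at hand to explain this step.

As far as these compounds go, it remains open whether the ring itself or the extra carbon count goes with the higher number. An open-chain pentyl group or a cyclopropyl group at this position would help separate the two.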